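A few compounds are considered here, and "the series" means these few. Any claim that something is new, unique, unknown or untested is made for them only; others in the source may bear on it.

Measured so far in this study:
compound 1, `O=[N+]([O-])c1ccccc1CNc1cccc2[nH]ncc12`: 25%
compound 2, `N#Cc1cc(NCc2ccccc2[N+](=O)[O-])c2cn[nH]c2c1`: 7%

In an assay for inhibition of Indoleamine 2,3-dioxygenase 1 (Homo sapiens), with stated times of 10 min and 60 min, tested at 10 uM (a higher number here means a stronger effect of the compound at the concentration tested, a lower number a weaker effect), compound 2 stands lowest of the two numbers; its nearest neighbour is compound 1, with a gap beyond the scatter. Among the compounds with values here, the single measured step, a number 18 percentage points lower from compound 1 to compound 2 (beyond the scatter), is the only comparison available. Compound 3, `COC(=O)c1cc(NCc2ccccc2[N+](=O)[O-])c2cn[nH]c2c1`, differs from compound 2 by methoxycarbonyl in place of cyano on an aromatic carbon. Within the data shown here, no measured step exchanges one such group for another, so the step into compound 3 is expected to stay small, a number 5 percentage points higher from compound 2 to compound 3 (within the scatter), with either direction possible within the scatter. For compound 3 the expected value is 12%, in a range from 0% to 30%.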

Compound 3, a percentage reported as inhibition, at one concentration (the size of the read-out at that concentration, not a potency): 11%
Compound 3: the middle estimate sits 1 percentage points above what was measured, within the range that was stated.
By their numbers in this assay, from the lowest: compounds 2 and 3 (each within the scatter of the next); then compound 1.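

In this assay, a number 4 percentage points higher from compound 2 to compound 3 (within the scatter) leaves methoxycarbonyl and cyano indistinguishable at this position, although methoxycarbonyl is the larger group by heavy atoms. Measured against hydrogen, a number 14 percentage points lower from compound 1 to compound 3 (beyond the scatter) shows that the lower number is not confined to cyano, as a second group on this aromatic carbon also goes with it. Nothing available accounts for this result. From the compounds shown here alone, whether a carboxylic acid, an amine or a methyl group at this carbon would also go with a lower number than hydrogen remains open.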